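The source may hold more compounds than are shown below. What is called first, only, known or untested is meant among the compounds shown, and "the series" means these compounds.

Compound 1 `Cc1ccc(-c2c(C)c(-c3ccc4c(c3C)CCCO4)c(C(OC(C)(C)C)C(=O)O)c(C)c2NS(C)(=O)=O)cc1C` gives 24000 nM in an ADME assay on MT4 cells (Homo sapiens) for cytotoxicity, read by MTT assay, with a stated time of 4 days; a higher number here means that more compound is tolerated, a lower number that less compound is tolerated. Compound 2 `Cc1ccc(-c2c(C)c(-c3ccc(C)c(C)c3)c(C(OC(C)(C)C)C(=O)O)c(C)c2NS(=O)(=O)c2ccccc2)cc1C` gives 11000 nM in this assay. Compound 3 `Cc1ccc(-c2c(C)c(-c3ccccc3)c(C(OC(C)(C)C)C(=O)O)c(C)c2NS(C)(=O)=O)cc1C` reaches only the limit of the assay, > 50000 nM, in this assay.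

Compound 3 thus stands at the limit (the limit of > 50000 nM in this assay, at which 1 of the 3 values shown sits), with no number of its own. Compound 4 `Cc1ccc(-c2c(C)c(-c3ccc(C)c(C)c3)c(C(OC(C)(C)C)C(=O)O)c(C)c2NS(C)(=O)=O)cc1C` differs from it by 3,4-dimethylphenyl in place of phenyl on an aromatic carbon. Among the measured compounds shown here, the one measured step touching this position, an at least 2.0-fold higher number from compound 1 to compound 3 (0.31 log units; beyond the scatter), moved toward more tolerance when the phenyl entered; the change now runs the other way, so a lower number is expected. Its size cannot be fixed; compound 3 carries only a limit. Compound 2, also bearing the 3,4-dimethylphenyl but with another sulfonamide, gives 11000 nM. Compound 4 is therefore expected near 25000 nM (range 10000 nM to 60000 nM), the expected step being an at least 2.0-fold lower number from compound 3 to compound 4 (0.30 log units; that floor lies within the scatter).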

Compound 4, half-maximal cytotoxic concentration: 15000 nM
Beside the measured number, compound 4's estimate is 1.7-fold (0.22 log units) above it, and the stated range covers the measured number.
By their numbers in this assay, from the lowest: compounds 2, 4 and 1 (each within the scatter of the next, the first and the last beyond it). At a limit, above all of these: compound 3.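

In this assay, 3,4-dimethylphenyl in place of phenyl on this aromatic carbon gives an at least 3.3-fold lower number from compound 3 to compound 4 (0.52 log units; beyond the scatter) and so separates the two aryl groups beyond the scatter. The other two steps stay within the scatter: a 1.4-fold higher number from compound 2 to compound 4 (0.13 log units; within the scatter) on exchanging phenyl for methyl on the sulfonyl sulfur, and a 1.6-fold lower number from compound 1 to compound 4 (0.20 log units; within the scatter) on exchanging the larger bicyclic group for 3,4-dimethylphenyl. Compound 3 carries a limit and no number of its own: the limit of > 50000 nM in this assay, at which 1 of the 4 values shown sits.

Open, from the compounds shown here alone, is whether a single methyl on the phenyl already produces this step. Also open, going by these compounds, is how a fluorine, a methoxy group or a pyridyl ring would read at this position.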